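Cytotoxicity in the thiourea series: the naphthyl analogue

A few compounds are considered here, and "the series" means these few. Any claim that something is new, unique, unknown or untested is made for them only; others in the source may bear on it.

Compound 3 `O=C(NC(=S)N1CCc2c(OCCCCCOc3ccc(Cl)cc3)cccc21)C1CCCCC1` carries a cyclohexyl group on the carbonyl carbon of the shared core. In an ADME assay on Huh-7 cells (Homo sapiens) for cytotoxicity (on this read-out lower numbers stand for higher toxicity in this test and higher numbers for lower toxicity in this test), compound 3 reaches only a limit, > 50000 nM. Compound 1 `O=C(NC(=S)N1CCc2c(OCCCCCOc3ccc(Cl)cc3)cccc21)c1ccc(Cl)cc1`, with a 4-chlorophenyl group in that place, gives 21700 nM in this assay. Compound 2 `CC(C)(C)c1ccc(C(=O)NC(=S)N2CCc3c(OCCCCCOc4ccc(Cl)cc4)cccc32)cc1`, the 4-(tert-butyl)phenyl analogue, also stands at a limit in this assay, > 50000 nM. The step of an at least 2.3-fold higher number from compound 1 to compound 3 (0.36 log units; beyond the scatter) and the step of an at least 2.3-fold higher number from compound 1 to compound 2 (0.36 log units; beyond the scatter) both move away from toxicity; the step that the two limits leave unreadable from compound 2 to compound 3 cannot be read, as shown by the limit of > 50000 nM in this assay, at which 2 of the 3 values shown sit.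

Compound 4 `O=C(NC(=S)N1CCc2c(OCCCCCOc3ccc(Cl)cc3)cccc21)c1ccc2ccccc2c1` differs from compound 3 in one place: naphthalen-2-yl in place of cyclohexyl on a carbonyl carbon. For the measured compounds named here, no measured step exchanges cyclohexyl for an aromatic group of this size, and the two aryl compounds 1 and 2 sit on either side of the limit. Compound 4 is therefore expected to land near 30000 nM, within 12000 nM to 70000 nM. The expected step of an at least 1.6-fold lower number from compound 3 to compound 4 (0.22 log units; that floor lies within the scatter) is estimated to be small, quite possibly within the scatter.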

Compound 4, half-maximal cytotoxic concentration: > 50000 nM
Compound 4: only a limit was reported (the forecaster's own chance of this, stated with the estimate: 45%); middle value at least 1.6-fold (0.22 log units) from the limit.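

In this assay, putting naphthalen-2-yl in place of 4-chlorophenyl on the carbonyl carbon gives an at least 2.3-fold higher number from compound 1 to compound 4 (0.36 log units; beyond the scatter). Compound 1 thus remains the only one of the four compounds with a number rather than a limit, and among these compounds a second aromatic ring in this place does not bring the read-out down to the level of compound 1. The steps among compound 2, compound 3 and compound 4 cannot be read, so no order among these three can be given, and the reason lies in the assay ceiling: the limit of > 50000 nM in this assay, at which 3 of the 4 values shown sit.

Open, going by these compounds, is whether the lower number of compound 1 is specific to the chloro group, which a 4-bromophenyl or 4-methoxyphenyl group in the same place would test. Also open, on these data alone, is how an amine or a carboxylic acid on that aromatic ring would read.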